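This account rests on a few compounds, and the source may have more. Where it says the series, first, only, none or still open, it means among the compounds named here.

Measured compounds, cytotoxicity in an ADME assay on THP-1 cells (Homo sapiens) for cytotoxicity, read by flow cytometry and propidium iodide staining, with a stated time of 72 h; on this read-out higher numbers stand for weaker inhibition and lower numbers for stronger inhibition:
- compound 1, `COc1cccc(-c2cc(=O)c3cc(NC(C)=O)ccc3o2)c1`: 10000 nM
- compound 2, `COc1ccc(-c2cc(=O)c3cc(NC(C)=O)ccc3o2)cc1`: 74000 nM
- compound 3, `COc1cccc(-c2cc(=O)c3cc(N)ccc3o2)c1`: a limit of the assay, > 125000 nM

Among the measured compounds shown here, the pairing of compound 1 with compound 3 is the only measured step: hydrogen in place of acetyl on a nitrogen on an aromatic ring. It gives an at least 12-fold higher number from compound 1 to compound 3 (1.09 log units; beyond the scatter). Compound 3 sits at the limit (the limit of > 125000 nM in this assay, at which 1 of the 3 values shown sits), so the true size of this step is open upward.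

Compound 2 carries the same atoms as compound 1 joined differently; the difference between the two cores is not broken down here. Within this assay compound 2 shows the higher of the two measured numbers, and compound 1 the lower, a gap beyond the scatter.

The unmeasured compound 4, `COc1ccc(-c2cc(=O)c3cc(N)ccc3o2)cc1`, is related to compound 2 in the same way that compound 3 is related to compound 1: hydrogen in place of acetyl on a nitrogen on an aromatic ring. The place of the change reads word for word the same in both pairs, so it is the same change, here made on the core of compound 2.

If the change acts on the core of compound 2 as it did on the core of compound 1, the expected step is a 2.7-fold higher number from compound 2 to compound 4 (0.43 log units; beyond the scatter). That expectation rests on compound 2 starting at 74000 nM and on the measured step of an at least 12-fold higher number from compound 1 to compound 3 (1.09 log units; beyond the scatter). Compound 4 is therefore expected to land near 200000 nM, within 100000 nM to 600000 nM, most probably reported by this assay only as a limit.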

Compound 4, half-maximal inhibitory concentration: 124000 nM
Compound 4: the middle estimate sits 1.6-fold (0.21 log units) above what was measured; measured number inside the range.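

In this assay the acetamido to amino change gives a 1.7-fold higher number from compound 2 to compound 4 (0.22 log units; within the scatter), so on the core of compound 2 its effect cannot be told apart from the scatter. Set beside the earlier step, the change does not carry over in size from one core to the other: the same change on two cores in this assay, an at least 12-fold higher number (1.09 log units; beyond the scatter) from compound 1 to compound 3 and a 1.7-fold higher number (0.22 log units; within the scatter) from compound 2 to compound 4, at least 7.4-fold (0.87 log units) apart, beyond the scatter of two such steps. Compound 3 stands at a limit of the assay, so the earlier step is a bound and not a size, and two pairs give neither a reason for the gap nor a rule for any further core: the limit of > 125000 nM in this assay, at which 1 of the 4 values shown sits.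

The compounds shown leave open whether the gap between the two steps goes with the way the methoxy group is joined in each core, or would also appear on cores carrying a hydroxyl group or a chlorine in its place. They also leave open how other groups on the same nitrogen, such as propionyl or methanesulfonyl, would read in this assay on either core.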